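A few compounds are considered here, and "the series" means these few. Any claim that something is new, unique, unknown or untested is made for them only; others in the source may bear on it.

Measured so far:
compound 1, `COc1cc(OCc2cccc(-c3ccc(C(F)(F)F)cn3)c2)c2cc(-c3cn4nc(OC)sc4n3)oc2c1` — > 2 h
compound 2, `CNC(=O)c1ccc(-c2nc(COc3cc(OC)cc4oc(-c5cn6nc(OC)sc6n5)cc34)cs2)cc1` — 0.517 h

Compound 1, with the structure `COc1cc(OCc2cccc(-c3ccc(C(F)(F)F)cn3)c2)c2cc(-c3cn4nc(OC)sc4n3)oc2c1`, was tested in an ADME assay on microsomes from liver (Rattus norvegicus) for metabolic stability (a lower number here means that the compound disappears faster, a higher number that the compound lasts longer), and gave only a limit, > 2 h, so its exact half-life is not known. Compound 2, `CNC(=O)c1ccc(-c2nc(COc3cc(OC)cc4oc(-c5cn6nc(OC)sc6n5)cc34)cs2)cc1`, is the second measured compound and gives 0.517 h in this assay. Within the data shown here, no single-point step links the two, so the pair only shows that one sits at the limit and the other below it; the limit of > 2 h in this assay, at which 1 of the 2 values shown sits, is all that fixes where compound 1 stands.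

Compound 3, `COc1cc(OCc2cccc(-c3ccc(C#N)cc3)c2)c2cc(-c3cn4nc(OC)sc4n3)oc2c1`, is not yet measured. It differs from compound 1 by 4-cyanophenyl in place of 5-(trifluoromethyl)pyridin-2-yl on an aromatic carbon, at an aromatic carbon of a six-membered aromatic ring of carbon only, meta to a large group. Both the leaving and the entering group carry one hydrogen-bond acceptor and no charge.

With compound 1 known only as a limit, the size of the step cannot be anchored; a step that stays within the scatter, or a modest fall, is expected. Compound 3 is expected to give 1.5 h, between 0.6 h and 4 h, which means an estimated step of an at least 1.3-fold lower number from compound 1 to compound 3 (0.12 log units; that floor lies within the scatter).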

Compound 3, half-life: 1.67 h
For compound 3 the middle estimate is 1.1-fold (0.05 log units) below the measured one; the measured number falls inside the stated range.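

Among these compounds, putting 4-cyanophenyl in place of 5-(trifluoromethyl)pyridin-2-yl on an aromatic carbon gives the first step at this position in this assay: an at least 1.1-fold lower number from compound 1 to compound 3 (0.07 log units; that floor lies within the scatter). With this change, compound 3 gives a measured half-life of 1.67 h, so the position now has an exact number. Compound 1 stays a limit, > 2 h, so the step is only a floor, and the true change may be small or much larger, with one value alone setting how far it can be read: the limit of > 2 h in this assay, at which 1 of the 3 values shown sits.

The compounds shown leave open how much of the step belongs to the ring nitrogen and how much to the exchange of trifluoromethyl for nitrile, two differences that arrive together in this single change. They also leave open how this assay would respond to a simple phenyl, a carboxylic acid or a morpholine at this place on the ring, and no exact half-life is available for compound 1 against which any of these could be set.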